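The source may report more compounds than this note shows. Statements on the series, on what has been measured and on what is new or still open speak of the compounds shown alone.

Two compounds of a shared core carry a basic amine at the far end of an ether chain and have been tested in a functional assay on MCF7 cells (Homo sapiens) for cytotoxicity, read by MTT assay, with a stated time of 72 h; a lower number here means a stronger inhibitor, a higher number a weaker inhibitor. Compound 1 `COc1c(OCCCCN2CCN(C)CC2)cc(O)c2c(=O)cc(-c3ccc(F)cc3)oc12` gives 3860 nM there. Compound 2 `CCN(CC)CCCOc1c(OCc2ccccc2)cc(O)c2c(=O)cc(-c3ccccc3)oc12` gives 3210 nM, the lower of the two numbers, but the gap to compound 1 lies within the scatter of this assay, so the two values are not distinguishable on the evidence available. Compound 3 `CN1CCN(CCCOc2c(OCc3ccccc3)cc(O)c3c(=O)cc(-c4ccccc4)oc23)CC1` has not yet been measured. It departs from compound 2 in one place: 4-methylpiperazin-1-yl in place of diethylamino on a saturated chain carbon, three bonds along the chain from an oxygen on an aromatic ring. Going by the values given here, no measured pair in this set isolates that change, so there is no direct guide to its size. Among the compounds with values here, the only pointer is that compound 1, which itself carries a 4-methylpiperazin-1-yl group on its chain, sits at 3860 nM, close to compound 2. Compound 3 is therefore expected to stay near compound 2, with a step of a 1.1-fold higher number from compound 2 to compound 3 (0.04 log units; within the scatter) that should not exceed the scatter in either direction. The expected value for compound 3 in this assay is 3500 nM, within a range from 1500 nM to 8000 nM.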

Compound 3, half-maximal inhibitory concentration: 1020 nM
Compound 3: the middle estimate sits 3.4-fold (0.54 log units) above what was measured; measured number below the stated range.
By their numbers in this assay, from the lowest: compound 3; then compounds 2 and 1 (each within the scatter of the next).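

In this assay, putting 4-methylpiperazin-1-yl in place of diethylamino on a saturated chain carbon, three bonds along the chain from an oxygen on an aromatic ring, brings a 3.1-fold lower number from compound 2 to compound 3 (0.50 log units; beyond the scatter), a modest step but one that clears the scatter. Going by these compounds alone, this is the first pair in the set in which the terminal amine alone changes, so it shows that the identity of that amine matters at this position, which compounds 1 and 2, differing in more than one place, could not show. Nothing available bears on the origin of this step.

From the compounds shown here alone, it remains open whether a morpholine or a piperidine at the end of the same chain would read like 4-methylpiperazin-1-yl or like diethylamino, and whether a longer chain carrying 4-methylpiperazin-1-yl would keep the step. The finding also rests on a single pair in this assay, so whether the same exchange gives a similar step with a fluorine on the outer phenyl ring, or with a methoxy group in place of the benzyloxy group, is unsettled.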